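From pyridin-4-yl to piperazin-1-yl on the shared core

The source may hold more compounds than are shown below. What is called first, only, known or untested is meant among the compounds shown, and "the series" means these compounds.

In a functional assay on HepG2 cells (Homo sapiens) for inhibition, read by MTT assay, with a stated time of 72 h (a higher number here means a weaker inhibitor, a lower number a stronger inhibitor), compound 1 `COc1ccc(-c2cc(C(=O)N3CCC4(CC3)CC(=O)c3nn(C(C)(C)C)cc3O4)c3ccccc3n2)cc1OC` gives 1560 nM, compound 2 `CC(C)(C)n1cc2c(n1)C(=O)CC1(CCN(C(=O)c3cc(-c4ccccn4)nc4ccccc34)CC1)O2` gives 1500 nM and compound 3 `CC(C)(C)n1cc2c(n1)C(=O)CC1(CCN(C(=O)c3cc(-c4ccncc4)nc4ccccc34)CC1)O2` gives 380 nM, the lowest number of the three and so the strongest inhibitor among them. Compound 4 `CC(C)(C)n1cc2c(n1)C(=O)CC1(CCN(C(=O)c3cc(N4CCNCC4)nc4ccccc34)CC1)O2` keeps the shared core but carries piperazin-1-yl in place of pyridin-4-yl on an aromatic carbon, next to the ring nitrogen: piperazin-1-yl in place of pyridin-4-yl on an aromatic carbon.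

Three measured swaps at this same carbon bear on the change. Replacing 3,4-dimethoxyphenyl with pyridin-2-yl gave a 1.0-fold lower number from compound 1 to compound 2 (0.02 log units; within the scatter), and replacing it with pyridin-4-yl gave a 4.1-fold lower number from compound 1 to compound 3 (0.61 log units; beyond the scatter). Replacing pyridin-2-yl with pyridin-4-yl gave a 3.9-fold lower number from compound 2 to compound 3 (0.60 log units; beyond the scatter). All three put one aromatic ring in place of another, so none tests a non-aromatic ring here, and the guide is only indirect. Both other groups tried here sit higher than compound 3, so a modest rise in this assay is expected, with an estimated 2.4-fold higher number from compound 3 to compound 4 (0.37 log units; beyond the scatter). The estimate for compound 4 is 900 nM, within an expected range of 250 nM to 3500 nM.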

Compound 4, half-maximal inhibitory concentration: 8570 nM
The estimate for compound 4 lay 9.5-fold (0.98 log units) below the measured number, and the stated range ends below it.
By their numbers in this assay, from the lowest: compound 3; then compounds 2 and 1 (each within the scatter of the next); then compound 4.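

In this assay piperazin-1-yl on this aromatic carbon gives a 23-fold higher number from compound 3 to compound 4 (1.35 log units; beyond the scatter) and also a 5.7-fold higher number from compound 2 to compound 4 (0.76 log units; beyond the scatter) and a 5.5-fold higher number from compound 1 to compound 4 (0.74 log units; beyond the scatter), which makes compound 4 the weakest inhibitor of the four. The earlier swaps exchanged only one aromatic ring for another, and this first non-aromatic ring, with the same count of heavy atoms as pyridin-4-yl, gives a higher number than all three aromatic groups shown. No measurement here accounts for this rise.

The compounds shown leave open whether the rise goes with the loss of aromaticity or with the hydrogen-bond donor that piperazin-1-yl brings. Morpholin-4-yl, 4-methylpiperazin-1-yl or piperidin-1-yl at this carbon would help to separate these two changes.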